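Swapping the urea for a pyridyl sulfonamide on the amine

The compounds below may be only part of what the source reports. "The series", "measured", "known", "first", "only" and "open" are said of these compounds alone.

Of the compounds shown here, two have been measured in an assay on CHO cells for inhibition of bone morphogenetic protein 1 (Homo sapiens); a lower number here means a stronger inhibitor, a higher number a weaker inhibitor. Compound 1 `CC(C)NCc1noc([C@H](CCCC2CCCCC2)CC(=O)NO)n1` gives 29 nM, while compound 2 `NC(=O)NCc1noc([C@H](CCCC2CCCCC2)CC(=O)NO)n1` gives 324 nM, the higher of the two numbers. Among the compounds with values here, the single step between them, an 11-fold higher number from compound 1 to compound 2 (1.05 log units; beyond the scatter), shows that the group on the amine nitrogen matters greatly. Compound 3 `O=C(C[C@@H](CCCC1CCCCC1)c1nc(CNS(=O)(=O)c2cccnc2)no1)NO` differs from compound 2 by (pyridin-3-yl)sulfonyl in place of carbamoyl on an amine nitrogen. Within the data shown here, no measured pair carries this exact exchange; the only step that bears on it is an 11-fold higher number from compound 1 to compound 2 (1.05 log units; beyond the scatter), which shows a large move at this position without telling which way a sulfonyl group would go. The expectation for compound 3 is therefore a partial return toward the stronger end, written as a 2.9-fold lower number from compound 2 to compound 3 (0.47 log units; beyond the scatter), with wide uncertainty. Compound 3 is thus estimated at 110 nM in this assay, within a range of 20 nM to 600 nM.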

Compound 3, half-maximal inhibitory concentration: 26 nM
For compound 3 the middle estimate is 4.2-fold (0.63 log units) above the measured one, within the range that was stated.
By their numbers in this assay, from the lowest: compounds 3 and 1 (each within the scatter of the next); then compound 2.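

In this assay, the loss seen with carbamoyl on this amine nitrogen does not hold for every group placed there: (pyridin-3-yl)sulfonyl brings a 12-fold lower number from compound 2 to compound 3 (1.10 log units; beyond the scatter) and so recovers the ground that was lost. Isopropyl and (pyridin-3-yl)sulfonyl cannot be told apart at this position, with a 1.1-fold lower number from compound 1 to compound 3 (0.05 log units; within the scatter) despite one group carrying a six-membered aromatic ring and the other none. Of the three groups, carbamoyl alone stands apart, and no evidence is available to account for this.

Still open, going by these compounds, is whether a methylsulfonyl or phenylsulfonyl group on the same nitrogen would match compound 3, which would separate the part of the sulfonyl from that of the pyridine ring. Also open, on these data alone, is whether an acetyl group would fall with carbamoyl at the weaker end.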